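Compound 2 and its cyclopropyl counterpart, compound 3

The source may report more compounds than this note shows. Statements on the series, on what has been measured and on what is new or still open speak of the compounds shown alone.

In an ADME assay on microsomes from liver (Rattus norvegicus) for metabolic stability (a higher number here means faster removal of the compound, a lower number slower removal), the compounds measured so far stand as follows:
compound 1 `CNc1nc(Cl)nc(NC2(C#N)CCCCC2)n1` gives 867 mL/min/kg
compound 2 `CNc1nc(NC2(C#N)CCCCC2)nc(-n2cnc(C#N)n2)n1` gives 210 mL/min/kg

Compound 2 holds the lower of the two numbers. Compound 3 `CNc1nc(NC2(C#N)CCCCC2)nc(C2CC2)n1` is still unmeasured. It carries cyclopropyl in place of 3-cyano-1H-1,2,4-triazol-1-yl on an aromatic carbon. For the measured compounds named here, only one measured step bears on this place: the same triazolyl group replaced chloro there, and the result was a 4.1-fold lower number from compound 1 to compound 2 (0.62 log units; beyond the scatter) in this assay as a modest change. Going by the values given here, no measured compound carries cyclopropyl, so that single step offers only a loose guide. Compound 1, which lacks the triazolyl group, stands at 867 mL/min/kg and so a modest step upward is expected once compound 3 gives that group up, probably no larger than the measured one. The expected change is a 2.1-fold higher number from compound 2 to compound 3 (0.33 log units; beyond the scatter) on this reading. For compound 3 the estimated clearance is 450 mL/min/kg with 170 mL/min/kg to 1000 mL/min/kg as the expected range.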

Compound 3, clearance: 276 mL/min/kg
Compound 3: middle estimate off by 1.6-fold (0.21 log units), on the high side; measured number inside the range.
By their numbers in this assay, from the lowest: compounds 2 and 3 (each within the scatter of the next); then compound 1.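

In this assay, cyclopropyl in place of 3-cyano-1H-1,2,4-triazol-1-yl gives a 1.3-fold higher number from compound 2 to compound 3 (0.12 log units; within the scatter) and so shows that two very different groups, one of carbon only with no hydrogen-bond acceptors and one holding nitrogen atoms and a nitrile, cannot be told apart at this place on the shared core. Cyclopropyl in place of chloro gives a 3.1-fold lower number from compound 1 to compound 3 (0.50 log units; beyond the scatter) and joins a 4.1-fold lower number from compound 1 to compound 2 (0.62 log units; beyond the scatter) as a second modest step in the same direction, so the lower number no longer rests on the triazolyl group alone. Among these three compounds, chloro is the group that stands apart, and neither the nitrogen atoms nor the triple bond of the triazolyl group are needed to reach the lower number.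

As far as these compounds go, whether the same holds for other groups at this place stays open, for instance an amine, a methoxy group, a longer alkyl chain or plain hydrogen, any of which could show whether chloro alone is the exception. Nothing at hand explains why these numbers fall as they do.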